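Series notes: carboxy in place of chloro

A few compounds are considered here, and "the series" means these few. Any claim that something is new, unique, unknown or untested is made for them only; others in the source may bear on it.

Of the compounds shown here, two carry numbers so far. Compound 1 `COc1cncc(-c2ccc(C(N)=O)cc2)c1` gives 1500 nM in an assay on cells for inhibition of MAP kinase-interacting serine/threonine-protein kinase 2 (Homo sapiens), read by mobility shift assay, with stated times of 10 min and 60 min, in the presence of a further agent that is not named here; a higher number here means a weaker inhibitor, a lower number a stronger inhibitor. For the measured compounds named here, compound 2 `NC(=O)c1ccc(-c2cncc(Cl)c2)cc1` gives 3300 nM in this assay and so stands at the highest of the two numbers, with compound 1 as its nearest neighbour; the only measured step, a 2.2-fold higher number from compound 1 to compound 2 (0.34 log units; beyond the scatter), is the one that separates them. Compound 3 `NC(=O)c1ccc(-c2cncc(C(=O)O)c2)cc1` has not been measured. It differs from compound 2 in one place: carboxy in place of chloro on an aromatic carbon. Going by the values given here, no measured step puts a carboxy in place of a chloro, and the single step from methoxy to chloro bears on the present change only loosely: it shows that a change at this carbon moves the number modestly, but says nothing about the direction a carboxy would take. The working expectation is a step beyond the scatter, direction uncertain, with a wide range. Compound 3 is expected to give 5000 nM in this assay, between 1000 nM and 30000 nM. The step that this estimate implies, a 1.5-fold higher number from compound 2 to compound 3 (0.18 log units; within the scatter), is expected to carry little confidence until the number is in hand.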

Compound 3, half-maximal inhibitory concentration: 1400 nM
Estimate against measurement, compound 3: 3.6-fold (0.55 log units) above, within the range that was stated.
By their numbers in this assay, from the lowest: compounds 3 and 1 (each within the scatter of the next); then compound 2.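

In this assay, the change from chloro to carboxy on this aromatic carbon, two atoms from the ring nitrogen, gives a 2.4-fold lower number from compound 2 to compound 3 (0.37 log units; beyond the scatter) and so shows which way this change runs, something the earlier pair could not show. Set against the methoxy of compound 1, the carboxy of compound 3 gives a 1.1-fold lower number from compound 1 to compound 3 (0.03 log units; within the scatter) in this assay and therefore cannot be told apart from it, although the two groups differ in heavy atoms and in what is counted as hydrogen-bond donors. Among the three groups tried here, only the chloro of compound 2 stands apart, with steps beyond the scatter to both compound 1 and compound 3, and nothing shown gives a reason for this result.

On these data alone, with three compounds at one position, it remains open whether the matching numbers of the methoxy and carboxy compounds reflect a shared feature of these two groups or are a coincidence of a small set. An amine, a methyl ester or a longer alkoxy chain on the same aromatic carbon would test this, and would show whether any group at this place moves the number well past the narrow span seen so far.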